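Compound 4: dimethylamino in place of 1H-imidazol-1-yl

This account rests on a few compounds, and the source may have more. Where it says the series, first, only, none or still open, it means among the compounds named here.

In a functional assay on ECa-109 cells (Homo sapiens) for antiproliferative activity, read by MTT assay, with a stated time of 48 h (a higher number here means a weaker inhibitor, a lower number a stronger inhibitor), compound 1 (`Cn1cc(C2=C(c3nn(CCn4ccnc4)c4ncccc34)C(=O)N(c3ccccc3)C2=O)c2ccccc21`) gives 8770 nM and compound 2 (`Cn1cc(C2=C(c3nn(CCCn4ccnc4)c4ncccc34)C(=O)N(c3ccccc3)C2=O)c2ccccc21`) gives 1440 nM on the same read-out. Compound 3 (`Cn1cc(C2=C(c3nn(CCCn4ccnc4)c4ncccc34)C(=O)NC2=O)c2ccccc21`) gives > 100000 nM as a limit of the assay and not a number. Its position is therefore known only as the limit of > 100000 nM in this assay, at which 1 of the 3 values shown sits, and not as a measured potency.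

Compound 4 (`CN(C)CCCn1nc(C2=C(c3cn(C)c4ccccc34)C(=O)NC2=O)c2cccnc21`) keeps the amide hydrogen of compound 3 and differs only in the side chain, where 3-(1H-imidazol-1-yl)propyl becomes 3-(dimethylamino)propyl: dimethylamino in place of 1H-imidazol-1-yl on a saturated chain carbon, three bonds along the chain from an aromatic nitrogen.

For the measured compounds named here, no measured step exchanges this group. The closest guide is a modest side-chain step (a 6.1-fold lower number from compound 1 to compound 2 (0.78 log units; beyond the scatter)). The large step (an at least 69-fold higher number from compound 2 to compound 3 (1.84 log units; beyond the scatter)) lies on the amide-type nitrogen, which stays unchanged here. A modest step toward a lower number is therefore expected in this assay, although compound 4 may also return only a limit. The expected change is an at least 1.4-fold lower number from compound 3 to compound 4 (0.15 log units; that floor lies within the scatter) as an estimate only. The estimated value for compound 4 is 70000 nM (expected range 15000 nM to 150000 nM).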

Compound 4, half-maximal inhibitory concentration: > 100000 nM
Compound 4 ended at the assay's limit; the forecaster's own chance of this, stated with the estimate: 50%; middle value at least 1.4-fold (0.15 log units) away from the limit.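

In this assay, compound 3 and compound 4 both sit at a limit of the assay and not at a number, so no step between them can be read: the limit of > 100000 nM in this assay, at which 2 of the 4 values shown sit.

The compounds shown leave open whether dimethylamino in place of 1H-imidazol-1-yl changes the read-out when phenyl stands on the amide-type nitrogen, as in compound 2.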